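The source may hold more compounds than are shown below. What is called first, only, known or untested is meant among the compounds shown, and "the series" means these compounds.

Measured so far in an ADME assay on S9 fraction from liver (Homo sapiens) for metabolic stability, using NADPH, in the presence of a further agent that is not named here; on this read-out higher numbers stand for a longer-lived compound and lower numbers for a shorter-lived compound:
compound 1 `O=C(c1ccc(-c2cccc(NS(=O)(=O)c3ccc(F)cc3)c2)s1)c1cc(F)c(F)c(O)c1F` gives 0.533 h;
compound 2 `Cc1cccc(S(=O)(=O)Nc2cccc(-c3ccc(C(=O)c4cc(F)c(F)c(O)c4F)s3)c2)c1` gives 0.467 h.

Going by the values given here, compound 2 holds the lower of the two numbers, its only neighbour being compound 1 after a 1.1-fold lower number from compound 1 to compound 2 (0.06 log units; within the scatter), a step within the scatter. Compound 3 `O=C(c1ccc(-c2cccc(NS(=O)(=O)c3ccc(Cl)cc3)c2)s1)c1cc(F)c(F)c(O)c1F` is not yet measured. It differs from compound 2 by 4-chlorophenyl in place of 3-methylphenyl on a sulfonyl sulfur. Among the compounds with values here, the single measured step at this position, a 1.1-fold lower number from compound 1 to compound 2 (0.06 log units; within the scatter), stayed within the scatter. A step of the same kind is therefore expected for compound 3 in this assay, a 1.1-fold higher number from compound 2 to compound 3 (0.03 log units; within the scatter), with no direction claimed beyond the scatter. Compound 3 is estimated at 0.5 h, within 0.25 h to 1 h.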

Compound 3, half-life: 0.667 h
For compound 3 the middle estimate is 1.3-fold (0.13 log units) below the measured one; the measured number falls inside the stated range.
By their numbers in this assay, from the lowest: compounds 2, 1 and 3 (each within the scatter of the next).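

In this assay, chloro in place of fluoro on an aromatic carbon gives a 1.3-fold higher number from compound 1 to compound 3 (0.10 log units; within the scatter) and 4-chlorophenyl in place of 3-methylphenyl on a sulfonyl sulfur gives a 1.4-fold higher number from compound 2 to compound 3 (0.15 log units; within the scatter) in a second step at this position. Both steps lie within the scatter, so this read-out does not separate the three aryl groups on the sulfonyl sulfur. No evidence bearing on this result is available.

Going by these compounds, whether an amine or a carboxylic acid on this aryl ring would shift the half-life beyond the scatter stays open. So does whether a saturated ring such as cyclohexyl, in place of the aryl group, would do so.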